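Inverting both ring stereocentres of compound 3

The source may report more compounds than this note shows. Statements on the series, on what has been measured and on what is new or still open speak of the compounds shown alone.

The measured compounds:
compound 1, `CCCCCCCCN1CC(=O)N(C)[C@@H](Cc2ccc(-c3cc(OC)c(OC)c(OC)c3)cc2)C1=O`, 400 nM;
compound 2, `CCCCCCN1C(=O)[C@H](Cc2ccc(-c3cc(OC)c(OC)c(OC)c3)cc2)N(C)C(=O)[C@@H]1C`, 100 nM;
compound 3, `CCCCCCCCN1C(=O)[C@H](Cc2ccc(-c3cc(OC)c(OC)c(OC)c3)cc2)N(C)C(=O)[C@@H]1C`, 13 nM.

All three were tested in a functional assay for agonist activity at follicle-stimulating hormone receptor (Homo sapiens), read by a luciferase reporter; on this read-out lower numbers stand for an effect already at smaller amounts and higher numbers for an effect only at larger amounts of compound. Compound 3 gives the lowest number of the three, with the nearest being compound 2 and the furthest compound 1; the step of a 7.7-fold lower number from compound 2 to compound 3 (0.89 log units; beyond the scatter) and the step of a 31-fold lower number from compound 1 to compound 3 (1.49 log units; beyond the scatter) both lie beyond the scatter. The unmeasured compound 4, `CCCCCCCCN1C(=O)[C@@H](Cc2ccc(-c3cc(OC)c(OC)c(OC)c3)cc2)N(C)C(=O)[C@H]1C`, keeps every atom and bond of compound 3 and differs only in configuration: the two compounds have the same atoms and bonds and differ only in configuration as drawn: 2 of 2 stereo elements differ (all stereocentres are inverted: mirror images); a stereocentre at a saturated ring carbon is drawn S in compound 3 and R in compound 4; a stereocentre at a saturated ring carbon is drawn S in compound 3 and R in compound 4.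

Within the data shown here, no measured step concerns a change of configuration; the two steps that reach compound 3 alter a methyl or a chain and so do not speak to this one. Mirror-image pairs of this kind commonly differ widely in such a read-out, and compound 4 is therefore expected to give a considerably higher number than compound 3, roughly a step of a 77-fold higher number from compound 3 to compound 4 (1.89 log units; beyond the scatter). The estimate for compound 4 in this assay is 1000 nM, within a range from 100 nM to 10000 nM.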

Compound 4, half-maximal effective concentration: 1600 nM
Compound 4: middle estimate off by 1.6-fold (0.20 log units), on the low side; low and high end bracket the measured number.
By their numbers in this assay, from the lowest: compound 3; then compound 2; then compound 1; then compound 4.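

The earlier steps shown here changed a group, either a methyl on a saturated ring carbon or the length of a chain, whereas here every atom and bond stays in place. Inverting both ring stereocentres still gives a 120-fold higher number from compound 3 to compound 4 (2.09 log units; beyond the scatter) in this assay, so the drawn S arrangement at these two saturated ring carbons is clearly favoured over the R arrangement in this pair. The gap can be assigned to configuration alone, and to no added or lost group, because of a single feature of the pair: the fact that compounds 3 and 4 differ only in the configuration as drawn

Since both stereocentres change together, the compounds shown do not reveal how much each one contributes on its own. They also leave open how an ethyl or a hydroxymethyl in place of the methyl on the saturated ring carbon, or a longer chain on the ring nitrogen, would read out in this assay.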